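The source may hold more compounds than are shown below. What is called first, only, known or untested is meant among the compounds shown, and "the series" means these compounds.

Values in a functional assay on MCF7 cells (Homo sapiens) for inhibition, read by sulforhodamine B assay; on this read-out higher numbers stand for weaker inhibition of growth and lower numbers for stronger inhibition of growth
Compound 1 `Oc1cccc2[nH]c(-c3ccc(-c4ccc(-c5ccccc5)cc4)cc3)nc12` gives 2200 nM
Compound 2 `Oc1cccc2[nH]c(-c3ccc(-c4ccc(-c5ccc(OC(F)(F)F)cc5)cc4)cc3)nc12` gives 2210 nM
Compound 3 `Oc1ccc(-c2ccc(-c3ccc(-c4nc5c(O)cccc5[nH]4)cc3)cc2)cc1` gives 190 nM

Compound 3 has the lowest number of the three and so the strongest inhibition of growth, with its steps to both others beyond the scatter. Compound 4 `CN(C)c1ccc(-c2ccc(-c3ccc(-c4nc5c(O)cccc5[nH]4)cc3)cc2)cc1` carries dimethylamino in place of hydroxy on an aromatic carbon. Among the measured compounds shown here, three measured steps bear on this change. Adding hydroxy gave a 12-fold lower number from compound 1 to compound 3 (1.06 log units; beyond the scatter) and removing trifluoromethyl from the oxygen gave a 12-fold lower number from compound 2 to compound 3 (1.07 log units; beyond the scatter), while trifluoromethoxy gave only a 1.0-fold higher number from compound 1 to compound 2 (0.00 log units; within the scatter). For the measured compounds named here, no measured compound carries dimethylamino, so its own effect is unknown, but the hydroxy is lost. In this assay the expected step is a 3.7-fold higher number from compound 3 to compound 4 (0.57 log units; beyond the scatter), somewhat smaller than the two large steps. For compound 4 the estimated value is 700 nM, with an expected range from 170 nM to 2600 nM.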

Compound 4, concentration for 50% growth inhibition: 2310 nM
Compound 4: the middle estimate sits 3.3-fold (0.52 log units) below what was measured; the range from low to high includes it.
By their numbers in this assay, from the lowest: compound 3; then compounds 1, 2 and 4 (each within the scatter of the next).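

In this assay dimethylamino in place of hydroxy gives a 12-fold higher number from compound 3 to compound 4 (1.08 log units; beyond the scatter) and so loses the whole advantage seen with hydroxy at this position. Dimethylamino in place of hydrogen gives a 1.1-fold higher number from compound 1 to compound 4 (0.02 log units; within the scatter) and dimethylamino in place of trifluoromethoxy gives a 1.0-fold higher number from compound 2 to compound 4 (0.02 log units; within the scatter) so among these four compounds only the hydroxy compound 3 stands apart. No measurement here explains this difference.

From the compounds shown here alone, whether any other group can match hydroxy at this position stays open. A primary amine, a methoxy group and a carboxylic acid are not among the compounds shown.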